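Lengthening the hydroxyalkyl chain: an estimate for compound 3

A few compounds are considered here, and "the series" means these few. Any claim that something is new, unique, unknown or untested is made for them only; others in the source may bear on it.

Two compounds have so far been measured in an in vitro assay on Sf9 cells for inhibition of cytochrome P450 2J2 (Homo sapiens); on this read-out higher numbers stand for weaker inhibition and lower numbers for stronger inhibition:

compound 1 `O=C(CCCN1CCC(C(O)(c2ccccc2)c2ccccc2)CC1)c1ccc(CCO)cc1`: 1300 nM
compound 2 `COc1ccc(C(=O)CCCN2CCC(C(O)(c3ccccc3)c3ccccc3)CC2)cc1`: 7600 nM

Compound 1 stands at the lowest of the two numbers, and the nearest of the other compounds is compound 2. Within the data shown here, the only measured step, a 5.8-fold higher number from compound 1 to compound 2 (0.77 log units; beyond the scatter), came with methoxy in place of 2-hydroxyethyl on an aromatic carbon.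

Compound 3 `O=C(CCCN1CCC(C(O)(c2ccccc2)c2ccccc2)CC1)c1ccc(CCCO)cc1` is the next member of the series. It differs from compound 1 by hydroxymethyl in place of hydroxy on a saturated chain carbon, two bonds along the chain from an aromatic carbon. Among the measured compounds shown here, no measured step concerns this kind of change: the one step known concerns the replacement of the whole 2-hydroxyethyl group by methoxy, whereas compound 3 keeps a hydroxy-bearing chain and merely makes it one carbon longer. Without a comparable step to lean on, the expectation for compound 3 in this assay is a change no larger than the scatter, a 1.2-fold higher number from compound 1 to compound 3 (0.06 log units; within the scatter), with wide uncertainty in either direction. Compound 3 is therefore estimated at 1500 nM, with a range from 500 nM to 4500 nM.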

Compound 3, half-maximal inhibitory concentration: 1900 nM
Compound 3: middle estimate off by 1.3-fold (0.10 log units), on the low side, and the stated range covers the measured number.
By their numbers in this assay, from the lowest: compounds 1 and 3 (each within the scatter of the next); then compound 2.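

In this assay, 3-hydroxypropyl can stand in place of 2-hydroxyethyl on the aromatic carbon without a difference that can be read (a 1.5-fold higher number from compound 1 to compound 3 (0.16 log units; within the scatter)), so this one-carbon change in the chain leaves the number within the scatter. The separation from the methoxy compound also holds for this second hydroxy-bearing chain (a 4.0-fold lower number from compound 2 to compound 3 (0.60 log units; beyond the scatter)), and so, among the three compounds shown, both chains that end in hydroxy stand apart from compound 2, with no compound going against this. No independent measurement is available that bears on what lies behind either step.

The compounds shown leave open how far the chain can be extended, for example to 4-hydroxybutyl or a longer chain, and whether the shorter hydroxymethyl group on the aromatic carbon would fit the same picture. They also leave open whether the terminal hydroxy itself matters, which a methyl ether, an amine or a carboxylic acid at the end of the same chain would begin to test.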